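A few compounds are considered here, and "the series" means these few. Any claim that something is new, unique, unknown or untested is made for them only; others in the source may bear on it.

Three urea compounds have been measured in an ADME assay on the whole organism with Oryza sativa as the target, tested at 1 uM; on this read-out higher numbers stand for a weaker effect at the one concentration tested and lower numbers for a stronger effect. Compound 1 `Cc1ccccc1NC(=O)N[C@@H](C)c1ccccc1` gives 99% in this assay. Compound 2 `CCc1ccccc1NC(=O)N[C@@H](C)c1ccccc1` gives 100%. Compound 3 `CC(C)c1ccccc1NC(=O)N[C@H](C)c1ccccc1` gives 101%, and on these numbers compound 3 sits within the scatter of both compound 1 and compound 2. Among the compounds with values here, the only single change among the measured compounds is a number 1 percentage points higher from compound 1 to compound 2 (within the scatter). Compound 4 `CC(C)c1ccccc1NC(=O)N[C@@H](C)c1ccccc1` has not yet been measured; its difference from compound 3 is the two compounds have the same atoms and bonds and differ only in configuration as drawn: 1 of 1 stereo elements differ; a stereocentre at a saturated chain carbon is drawn R in compound 3 and S in compound 4. Within the data shown here, no measured step covers a change of configuration, so nothing here points to a shift beyond the scatter. Compound 4 is therefore expected to read 100%, within 92% to 106%, a step of a number 1 percentage points lower from compound 3 to compound 4 (within the scatter).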

Compound 4, a percentage reported as activity, at one concentration (the size of the read-out at that concentration, not a potency): 96%
Beside the measured number, compound 4's estimate is 4 percentage points above it; low and high end bracket the measured number.
By their numbers in this assay, from the lowest: compounds 4, 1, 2 and 3 (each within the scatter of the next).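

In this assay, drawing the stereocentre at the saturated chain carbon as S in place of R gives a number 5 percentage points lower from compound 3 to compound 4 (within the scatter) and so shows that this reversal of configuration, in this isopropyl compound, leaves the read-out inside the usual spread. The two other routes to compound 4 stay inside it too: a number 3 percentage points lower from compound 1 to compound 4 (within the scatter) with isopropyl in place of methyl on an aromatic carbon, and a number 4 percentage points lower from compound 2 to compound 4 (within the scatter) with methyl in place of hydrogen on a saturated chain carbon. The comparison of compound 3 with compound 4 isolates a single feature: the fact that compounds 3 and 4 differ only in the configuration as drawn. Still open, as far as these compounds go, is whether a different group on that aromatic carbon, such as an amine or a carboxylic acid in place of the isopropyl, would move the read-out beyond the scatter.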